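A Methyl Group on the Chain Carbon

The source may hold more compounds than are shown below. What is called first, only, known or untested is meant among the compounds shown, and "the series" means these compounds.

In a functional assay on SiHa cells (Homo sapiens) for cytotoxicity, read by MTT assay, with a stated time of 72 h (on this read-out higher numbers stand for weaker inhibition and lower numbers for stronger inhibition), compound 2 `O=c1c2ccccc2sn1Cc1ccccc1` gives 25100 nM. Compound 1 `C[C@@H](c1ccccc1)n1sc2ccccc2c1=O` gives 35900 nM and compound 3 `CC(C)Cn1sc2ccccc2c1=O` gives 38100 nM. Both lie within the usual scatter of compound 2, so these three numbers do not rank the compounds.

The unmeasured compound 4 `C[C@H](c1ccccc1)n1sc2ccccc2c1=O` differs from compound 2 as follows: methyl in place of hydrogen on a saturated chain carbon bound to an aromatic carbon and an aromatic nitrogen. In words, it has methyl in place of hydrogen on a saturated chain carbon bound to an aromatic carbon and an aromatic nitrogen. Compound 1 carries the same methyl on that carbon, but with the opposite handedness.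

Going by the values given here, the one measured step bearing on this change is a 1.4-fold lower number from compound 1 to compound 2 (0.16 log units; within the scatter), which removes the methyl from the opposite-handed form. The data do not show whether handedness matters here, so the expectation rests on that small step alone. The expected change is a 1.3-fold higher number from compound 2 to compound 4 (0.12 log units; within the scatter), which would stay within the scatter. Compound 4 is estimated at 33000 nM, with an expected range of 19000 nM to 56000 nM.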

Compound 4, half-maximal inhibitory concentration: 32300 nM
Compound 4: the middle estimate sits 1.0-fold (0.01 log units) above what was measured; the measured number falls inside the stated range.
By their numbers in this assay, from the lowest: compounds 2, 4, 1 and 3 (each within the scatter of the next).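

Adding the methyl in the second handedness gives a 1.3-fold higher number from compound 2 to compound 4 (0.11 log units; within the scatter), so both handed forms of this chain carbon now stay within the scatter of compound 2, which lacks the methyl. The effect of handedness can also be read directly in this assay, where the switch gives a 1.1-fold lower number from compound 1 to compound 4 (0.05 log units; within the scatter), so at this position the drawn configuration makes no difference that can be told from the scatter. This comparison isolates handedness alone, and the methyl plays no other part in it: the fact that compounds 1 and 4 differ only in the configuration as drawn

The compounds shown leave open whether a longer chain, an amine or a carboxylic acid on this chain carbon would move the number beyond the scatter. They also leave open whether handedness would matter with any such group in place of the methyl.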